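Aminomethyl in Place of a Hydroxy Ester: Expected Half-Life

The compounds below may be only part of what the source reports. "The series", "measured", "known", "first", "only" and "open" are said of these compounds alone.

Compound 1 `COC(=O)[C@@H](O)[C@H]1C(=O)N2C(C(=O)O)=C(C(C)(C)C)O[C@H]12` gives 6.2 h in an ADME assay, in phosphate buffer, at 28 degrees C, at pH 7.0 (a lower number here means that the compound disappears faster, a higher number that the compound lasts longer), the lowest of the three numbers, though all three sit within the scatter of each other. Compound 2 `Cn1cc([C@@H](O)[C@H]2C(=O)N3C(C(=O)O)=C(C(C)(C)C)O[C@H]23)nn1` gives 6.8 h and compound 3 `CC(C)(C)C1=C(C(=O)O)N2C(=O)[C@H]([C@H](O)c3ccncc3)[C@H]2O1` gives 6.4 h. The steps of a 1.1-fold higher number from compound 1 to compound 2 (0.04 log units; within the scatter) and a 1.0-fold higher number from compound 1 to compound 3 (0.01 log units; within the scatter) show that exchanging the group on the saturated chain carbon hardly moved this assay. Compound 4 `CC(C)(C)C1=C(C(=O)O)N2C(=O)[C@H](CN)[C@H]2O1` differs from compound 1 by aminomethyl in place of hydroxy(methoxycarbonyl)methyl on a saturated ring carbon. Among the compounds with values here, no measured step removes the whole hydroxy(methoxycarbonyl)methyl group or brings in aminomethyl, so the two steps bear on this change only loosely, and no shift beyond the scatter is expected. Compound 4 is therefore estimated to show a 1.0-fold lower number from compound 1 to compound 4 (0.01 log units; within the scatter), giving 6 h within a range of 2.5 h to 14 h.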

Compound 4, half-life: 1.2 h
Beside the measured number, compound 4's estimate is 5.0-fold (0.70 log units) above it; the whole stated range lies above it.
By their numbers in this assay, from the lowest: compound 4; then compounds 1, 3 and 2 (each within the scatter of the next).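

Unlike the exchanges on the saturated chain carbon, which all stayed within the scatter in this assay, replacing the whole hydroxy(methoxycarbonyl)methyl on the saturated ring carbon with aminomethyl gives (a 5.2-fold lower number from compound 1 to compound 4 (0.71 log units; beyond the scatter)), a step beyond the scatter. This position therefore does register a change in this assay when the entire group is exchanged, with the compound disappearing faster. Nothing available explains this drop.

Compound 4 loses the hydroxy ester and gains the amine in one step, so the compounds shown do not separate the two changes. As far as these compounds go, how a hydroxymethyl group or a longer aminoethyl chain would behave at this position stays open.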